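Ester and side-chain changes in the liver microsome series

The source may hold more compounds than are shown below. What is called first, only, known or untested is meant among the compounds shown, and "the series" means these compounds.

Compound 1 `CCCCCOC(=O)Cc1c(C(C)C)nc(CCCC)n(Cc2ccc(-c3ccccc3-c3noc(=O)[nH]3)cc2)c1=O` carries a pentyl ester; in an ADME assay on microsomes from liver (Homo sapiens) for metabolic stability, with a stated time of 30 min (on this read-out lower numbers stand for a less stable compound and higher numbers for a more stable compound), compound 1 gives 10.6%. Compound 2 `CCCCc1nc(C(C)C)c(CC(=O)OC2CC2)c(=O)n1Cc1ccc(-c2ccccc2-c2noc(=O)[nH]2)cc1` carries a cyclopropyl ester instead, and in this assay compound 2 gives 10.3%. Among the compounds with values here, the step of a number 0.3 percentage points lower from compound 1 to compound 2 (within the scatter) shows the two esters giving numbers within the scatter of each other, so compound 2 stands within the scatter of compound 1, the only other number so far.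

Compound 3 `CCCCc1nc(C)c(CC(=O)OC2CC2)c(=O)n1Cc1ccc(-c2ccccc2-c2noc(=O)[nH]2)cc1` is the next compound. It differs from compound 2 by methyl in place of isopropyl on an aromatic carbon. Within the data shown here, no measured step touches this position: the single step measured concerns the ester oxygen, and it was within the scatter. Among the measured compounds shown here, with no bearing step, no change beyond the scatter is expected here, and the step from compound 2 to compound 3 is estimated at a number 2.7 percentage points higher from compound 2 to compound 3 (within the scatter). For compound 3 the expected value in this assay is 13%, with a range from 5% to 28%.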

Compound 3, percent of the compound remaining: 34.5%
Compound 3: the middle estimate sits 21.5 percentage points below what was measured; measured number above the stated range.
By their numbers in this assay, from the lowest: compounds 2 and 1 (each within the scatter of the next); then compound 3.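

Methyl in place of isopropyl on an aromatic carbon gives a number 24.2 percentage points higher from compound 2 to compound 3 (beyond the scatter) in this assay. This position therefore moves the read-out where the ester oxygen did not, as the earlier change gave a number 0.3 percentage points lower from compound 1 to compound 2 (within the scatter). The finding rests on one pair, read on the cyclopropyl ester alone.

Nothing shown accounts for the size of this step.

From the compounds shown here alone, whether the same change holds on the pentyl ester of compound 1 stays open, as does the trend with hydrogen, ethyl or trifluoromethyl on this aromatic carbon. Also open, going by these compounds, is whether a shorter chain in place of butyl, or a carboxylic acid in place of the ester, would shift the number as far.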